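This account rests on a few compounds, and the source may have more. Where it says the series, first, only, none or still open, it means among the compounds named here.

In an ADME assay on microsomes from liver (Homo sapiens) for metabolic stability, read by LC-MS, with a stated time of 40 min, tested at 0.5 uM (on this read-out higher numbers stand for fast clearance and lower numbers for slow clearance), compound 1 `CC(C)(CO)S(=O)(=O)c1cccc(NC(=O)c2cccnc2N2CCC3(CC2)CC3)c1` gives 154 mL.min-1.g-1. Compound 2 `CC(C)(O)CNc1ccc(C(=O)Nc2cccc(S(=O)(=O)C3CCCC3)n2)c(N2CCC3(CC2)CC3)c1` gives > 399 mL.min-1.g-1, which is a limit of the assay and not a number. The record for this pair comes down to the limit of > 399 mL.min-1.g-1 in this assay, at which 1 of the 2 values shown sits. Compound 2 therefore stands on the fast-clearance side of compound 1, though how far beyond it cannot be read from the data.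

Compound 3 `O=C(Nc1cccc(S(=O)(=O)C2CCCC2)n1)c1ccc(NCCO)cc1N1CCC2(CC1)CC2` keeps the rest of compound 2 and alters one side chain, with hydroxymethyl in place of 1-hydroxy-1-methylethyl on a saturated chain carbon bound to a nitrogen on an aromatic ring. Put another way, 2-hydroxy-2-methylpropyl gives way to 2-hydroxyethyl. Among the measured compounds shown here, no measured pair shows what this change does in this assay. The expectation starts from compound 2, whose > 399 mL.min-1.g-1 is again only a limit. The expected step is an at least 1.2-fold lower number from compound 2 to compound 3 (0.09 log units; that floor lies within the scatter), a modest one towards slower clearance that may not clear the usual scatter. Compound 3 is estimated at 320 mL.min-1.g-1, with an expected range of 150 mL.min-1.g-1 to 650 mL.min-1.g-1, and it may itself be reported only as a limit.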

Compound 3, intrinsic clearance in microsomes: > 399 mL.min-1.g-1
Compound 3 was reported as a limit (the forecaster's own chance of this, stated with the estimate: 40%); at least 1.2-fold (0.09 log units) between middle value and limit.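

In this assay compound 3 gives > 399 mL.min-1.g-1, which is a limit of the assay and not a number. Among the compounds shown here, compound 2 stands at a limit too, so no step between compound 2 and compound 3 can be read: the limit of > 399 mL.min-1.g-1 in this assay, at which 2 of the 3 values shown sit. The compounds shown leave open how fast either is cleared, and whether 2-hydroxyethyl in place of 2-hydroxy-2-methylpropyl changes clearance at all.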